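This account rests on a few compounds, and the source may have more. Where it says the series, first, only, none or still open, it means among the compounds named here.

Three compounds share one core. Compound 1 `O=C(Nc1ccc(Oc2ccnc3[nH]ccc23)cc1)c1nn(-c2ccc(Br)cc2)ccc1=O` gives 7890 nM in a functional assay on MCF7 cells (Homo sapiens) for cytotoxicity, read by MTT assay, with a stated time of 72 h; a lower number here means a stronger inhibitor, a higher number a weaker inhibitor. Compound 2 `COc1ccc(-n2ccc(=O)c(C(=O)Nc3ccc(Oc4ccnc5[nH]ccc45)c(F)c3)n2)cc1` gives 55400 nM in this assay, and compound 3 `O=C(Nc1ccc(Oc2ccnc3[nH]ccc23)c(F)c1)c1nn(-c2ccc(Br)cc2)ccc1=O` gives 11600 nM in this assay. Among these three numbers compound 3 holds the second highest: the step of a 1.5-fold higher number from compound 1 to compound 3 (0.17 log units; within the scatter) stays within the scatter, whereas the step of a 4.8-fold lower number from compound 2 to compound 3 (0.68 log units; beyond the scatter) goes beyond it and counts as modest.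

Compound 4 `O=C(Nc1ccc(Oc2ccnc3[nH]ccc23)c(F)c1)c1nn(-c2ccc(Cl)c(F)c2)ccc1=O` differs from compound 3 by 4-chloro-3-fluorophenyl in place of 4-bromophenyl on an aromatic nitrogen. Of the measured steps, a 4.8-fold lower number from compound 2 to compound 3 (0.68 log units; beyond the scatter) concerns the same ring on the aromatic nitrogen and shows that exchanging one group there for another moves the number modestly; a 1.5-fold higher number from compound 1 to compound 3 (0.17 log units; within the scatter) concerns a different ring and lies within the scatter. Since chloro stands closer to bromo than methoxy does, and the fluoro merely joins it on that ring, compound 4 is expected to show a step of a 1.0-fold higher number from compound 3 to compound 4 (0.01 log units; within the scatter) that remains within the scatter. Compound 4 is therefore estimated at 12000 nM, with a range from 5000 nM to 30000 nM.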

Compound 4, half-maximal inhibitory concentration: 11600 nM
Compound 4: the middle estimate sits 1.0-fold (0.01 log units) above what was measured; measured number inside the range.
By their numbers in this assay, from the lowest: compounds 1, 3 and 4 (each within the scatter of the next); then compound 2.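

At the ring on the aromatic nitrogen, the change from 4-bromophenyl to 4-chloro-3-fluorophenyl leaves the reading in this assay unmoved (no change at the digits printed from compound 3 to compound 4 (within the scatter)). The one exchange seen there before had moved the number, and the new step (a 4.8-fold lower number from compound 2 to compound 4 (0.68 log units; beyond the scatter)) is of the same size, so among these compounds the 4-methoxyphenyl group stands apart, while 4-bromophenyl and 4-chloro-3-fluorophenyl cannot be told apart. Nothing at hand explains why these two groups read alike.

The compounds shown leave open whether the methoxy result reflects a wider trend, since only one such group appears at this position. On these data alone, how an amine or a carboxylic acid on this phenyl ring would compare also remains unknown.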